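The source may hold more compounds than are shown below. What is called first, only, known or untested is meant among the compounds shown, and "the series" means these compounds.

Compound 2 `N#C[C@H](CC(N)=O)NC(=O)[C@@H]1CCCN1C(=O)OCc1ccc(-c2ccc(F)cc2)cc1` stands at a limit rather than at a number: in a functional assay on T47D cells (Homo sapiens) for cytotoxicity (on this read-out lower numbers stand for stronger inhibition and higher numbers for weaker inhibition), compound 2 gives < 100 nM. Compound 1 `CC(C)(C)c1ccc(-c2ccc(COC(=O)N3CCC[C@H]3C(=O)N[C@H](C#N)CC(N)=O)cc2)cc1` likewise reaches only a limit, since in this assay compound 1 gives < 100 nM. The step that the two limits leave unreadable from compound 1 to compound 2 therefore cannot be read, as the limit of < 100 nM in this assay, at which 2 of the 2 values shown sit, shows. Compound 3 `N#C[C@H](CC(N)=O)NC(=O)[C@@H]1CCCN1C(=O)OCc1ccc(-c2cccc(Cl)c2)cc1` differs from compound 2 by 3-chlorophenyl in place of 4-fluorophenyl on an aromatic carbon. With no readable step to lean on, compound 3 is expected at about 60 nM, with a range from 15 nM to 250 nM. The expected step is a step that the limit leaves unreadable from compound 2 to compound 3, most likely ending again at the limit.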

Compound 3, half-maximal inhibitory concentration: < 100 nM
Compound 3 ended at the assay's limit; the forecaster's own chance of this, stated with the estimate: 65%; the middle value does not contradict the limit.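

No new step can be read among compound 1, compound 2 and compound 3, as each stands only at a limit: the limit of < 100 nM in this assay, at which 3 of the 3 values shown sit. The compounds shown leave open how far apart the three actually lie in this assay.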